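The compounds below may be only part of what the source reports. "The series", "measured", "known", "first", "only" and "open" are said of these compounds alone.

The measured compounds and their values in a functional assay on HeLa cells (Homo sapiens) for antiproliferative activity; on this read-out lower numbers stand for stronger inhibition and higher numbers for weaker inhibition:

Compound 1, `COCCO/N=C/c1c(N)ncnc1Oc1ccc2[nH]c(C)cc2c1F`, gives 308 nM.
Compound 2, `CO/N=C/c1c(N)ncnc1Oc1ccc2[nH]ccc2c1`, gives 1870 nM.
Compound 3, `COCCCO/N=C/c1c(N)ncnc1Oc1ccc2[nH]c(C)cc2c1F`, gives 346 nM.

Compound 3 stands second highest of these three numbers. Its nearest neighbour is compound 1, which differs by methoxymethyl in place of methoxy on a saturated chain carbon, two bonds along the chain from an oxygen on an unsaturated carbon; that step is a 1.1-fold higher number from compound 1 to compound 3 (0.05 log units; within the scatter). Going by the values given here, compound 2 gives a clearly higher number, but it differs from compound 3 in more than one place, so that pair gives no single step.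

Compound 4, `Cc1cc2c(F)c(Oc3ncnc(N)c3/C=N/O)ccc2[nH]1`, is not yet measured in this assay. It differs from compound 3 in one place: hydrogen in place of 3-methoxypropyl on an oxygen. Among the compounds with values here, no measured step removes this chain entirely. Within the data shown here, the only step touching it, a 1.1-fold higher number from compound 1 to compound 3 (0.05 log units; within the scatter), is within the scatter and shows merely that lengthening the chain changes little; whether the chain can be dropped altogether is untested. Compound 4 is therefore expected to show a modest rise, a 1.6-fold higher number from compound 3 to compound 4 (0.20 log units; within the scatter), with wide uncertainty. Compound 4 is estimated at 550 nM, within a range from 150 nM to 2000 nM.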

Compound 4, half-maximal inhibitory concentration: 472 nM
The estimate for compound 4 lay 1.2-fold (0.07 log units) above the measured number; low and high end bracket the measured number.
By their numbers in this assay, from the lowest: compounds 1, 3 and 4 (each within the scatter of the next); then compound 2.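

In this assay, taking the chain off the oxygen altogether gives a 1.4-fold higher number from compound 3 to compound 4 (0.13 log units; within the scatter) and a 1.5-fold higher number from compound 1 to compound 4 (0.19 log units; within the scatter) for the loss of 2-methoxyethyl. The earlier compounds shown here showed only that one chain could stand in for another, whereas these steps show that, among compounds 1, 3 and 4, a free hydroxy on this oxygen gives numbers within the scatter of those with either chain, so neither chain is required to keep the number in this range. Nothing measured here gives a reason for this result.

On these data alone, whether a longer chain, or a chain ending in an amine or a carboxylic acid, on this oxygen would stay in the same range remains open. As far as these compounds go, it is also open whether the hydroxy form would behave alike on the core of compound 2.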